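The compounds below may be only part of what the source reports. "The series", "measured", "known", "first", "only" and "open" are said of these compounds alone.

Measured so far:
compound 1 `COc1cc(-c2nnc3n([C@@H](C)c4ccc(F)cc4)cccc2-3)ccc1-n1cnc(C)c1`, in an ADME assay for permeability, in the apical to basolateral direction (a higher number here means that the compound crosses the layer faster, a lower number that the compound crosses the layer more slowly), compound 1 gives 9 nm/s
compound 2 `COc1cc(-c2nnc3n([C@@H](C)c4cc(F)cc(F)c4)cccc2-3)ccc1-n1cnc(C)c1`, in this assay compound 2 gives 85 nm/s

Compound 1 stands lowest of the two numbers; its nearest neighbour is compound 2, reached by a 9.4-fold higher number from compound 1 to compound 2 (0.98 log units; beyond the scatter). Compound 3 `COc1cc(-c2nnc3n([C@@H](C)c4ccc(F)cc4)cc(C)cc2-3)ccc1-n1cnc(C)c1` differs from compound 1 by methyl in place of hydrogen on an aromatic carbon, on the six-membered aromatic ring with one nitrogen of the shared core, two atoms from the ring nitrogen. Going by the values given here, the one measured step alters the fluorine pattern on the phenyl, not the core, so no step bears on this change. Compound 3 is expected near 15 nm/s, range 5 nm/s to 45 nm/s. The expected step of a 1.7-fold higher number from compound 1 to compound 3 (0.22 log units; within the scatter) stays within the scatter.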

Compound 3, apparent permeability: 48 nm/s
Beside the measured number, compound 3's estimate is 3.2-fold (0.51 log units) below it; the whole stated range lies below it.
By their numbers in this assay, from the lowest: compound 1; then compounds 3 and 2 (each within the scatter of the next).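

The position two atoms from the ring nitrogen on the shared core responds in this assay: methyl in place of hydrogen gives a 5.3-fold higher number from compound 1 to compound 3 (0.73 log units; beyond the scatter). The read-out therefore moves with a change on the core, not only with the fluorine pattern on the phenyl. Nothing at hand explains this step. Still open, on these data alone, is whether an ethyl, a methoxy or an amine at this position gives a step of similar direction and size. Also open, as far as these compounds go, is how this methyl behaves together with the 3,5-difluorophenyl of compound 2.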